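The compounds below may be only part of what the source reports. "The series", "measured", "known", "first", "only" and "open" are said of these compounds alone.

In a functional assay on the whole organism for positive allosteric modulation, with Mus musculus as the target (on this read-out higher numbers stand for an effect only at larger amounts of compound and lower numbers for an effect already at smaller amounts), three compounds sharing one core have been measured. Compound 1 `CCC(=O)N(c1ccc(OC)cc1)C1CCCC1N(C)C` gives > 50 mg/kg; > 50 mg/kg (2 entries), which is a limit of the assay and not a number. Compound 3 `CCC(=O)N(c1ccc(C#N)cc1)C1CCCC1N(C)C` gives > 50 mg/kg, again only a limit. Going by the values given here, compound 2 `CCC(=O)N(c1ccc([N+](=O)[O-])cc1)C1CCCC1N(C)C` gives 20 mg/kg, the only true number of the three. Compound 3 therefore has no exact value to serve as a starting point.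

Compound 4 `CCC(=O)N(c1ccc(C(C)=O)cc1)C1CCCC1N(C)C` differs from compound 3 by one change, acetyl in place of cyano on an aromatic carbon, para to a large group. Among the compounds with values here, one measured step bears on this position, cyano in place of nitro, which gave an at least 2.5-fold higher number from compound 2 to compound 3 (0.39 log units; beyond the scatter). That step is beyond the scatter and shows that the read-out can respond to the group at this place, but it is a single example and its size is known only as a limit. A modest shift towards a lower number is therefore expected, though another limit reading remains quite possible. The estimated change is an at least 1.2-fold lower number from compound 3 to compound 4 (0.09 log units; that floor lies within the scatter). Compound 4 is expected at 40 mg/kg, within an estimated range of 15 mg/kg to 100 mg/kg.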

Compound 4, dose for half-maximal effect: > 50 mg/kg
Compound 4 was reported as a limit; the forecaster's own chance of this, stated with the estimate: 60%; middle value at least 1.2-fold (0.09 log units) from the limit.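

In this assay, acetyl in place of nitro gives an at least 2.5-fold higher number from compound 2 to compound 4 (0.39 log units; beyond the scatter), so acetyl, like cyano before it, does not keep the true number that nitro gives at this place. Compound 4 gives > 50 mg/kg, a limit of the assay and not a number. The step from cyano to acetyl cannot be read, so the result does not put these two groups in any order, and all it shows for them is a shared limit: the limit of > 50 mg/kg in this assay, at which 2 of the 4 values shown sit.

On these data alone, how far compound 3 and compound 4 lie beyond that limit stays open. Also open, as far as these compounds go, is whether an amine, a carboxylic acid or a trifluoromethyl group at this place would give a true number in this assay, and how that number would stand against the one for nitro.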